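The source may hold more compounds than are shown below. What is called first, only, known or untested is meant among the compounds shown, and "the series" means these compounds.

Measured compounds in a functional assay on MGC-803 cells (Homo sapiens) for cytotoxicity, read by MTT assay, with a stated time of 72 h; on this read-out lower numbers stand for stronger inhibition and higher numbers for weaker inhibition:
- Compound 1, `COc1cc2ncnc(NNC(=S)NC(=O)c3ccccc3Cl)c2cc1OC`: 6440 nM
- Compound 2, `O=C(NC(=S)NNc1ncnc2ccccc12)c1ccc(F)cc1`: 3600 nM
- Compound 3, `O=C(NC(=S)NNc1ncnc2ccccc12)c1ccccc1Cl`: 9140 nM

Compound 1 holds the middle of the three values, yet neither gap to compound 2 nor to compound 3 reaches beyond the scatter of repeated measurements, so the three cannot be ranked with confidence. Compound 4, `COc1cc2ncnc(NNC(=S)NC(=O)c3ccccc3F)c2cc1OC`, keeps the core of compound 1 and differs from it in one place: fluoro in place of chloro on an aromatic carbon.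

Among the compounds with values here, only one measured step touches a halogen on that phenyl ring, a 2.5-fold higher number from compound 2 to compound 3 (0.40 log units; beyond the scatter), and it changes both the halogen and its position at once, so it bears on the present change only in part. Taken at face value, it hints that a fluorine-bearing ring may give a lower number than a chlorine-bearing one, but with a single step of that kind no firm direction can be set. Compound 4 is therefore expected to show a small drop in number, or none beyond the scatter, so that a 1.4-fold lower number from compound 1 to compound 4 (0.16 log units; within the scatter) is the estimated step. Compound 4 is estimated at 4500 nM, with a range from 2300 nM to 9000 nM.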

Compound 4, half-maximal inhibitory concentration: 2390 nM
For compound 4 the middle estimate is 1.9-fold (0.27 log units) above the measured one, and the stated range covers the measured number.
By their numbers in this assay, from the lowest: compounds 4, 2, 1 and 3 (each within the scatter of the next, the first and the last beyond it).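

In this assay, 2-fluorophenyl in place of 2-chlorophenyl on the carbonyl gives a 2.7-fold lower number from compound 1 to compound 4 (0.43 log units; beyond the scatter), a step beyond the scatter. Unlike a 2.5-fold higher number from compound 2 to compound 3 (0.40 log units; beyond the scatter), which changes the halogen and its position together, this step changes the halogen alone and leaves its place on the ring untouched, so at this position the identity of the halogen by itself moves the number. Nothing at hand accounts for this difference.

The compounds shown leave open whether fluoro would give a similar step on the core of compound 3, which lacks the two methoxy groups, and whether the position itself matters on the core of compound 1. They also leave open how a plain hydrogen, a methyl, a methoxy or a trifluoromethyl group would fare in this same place.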